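This account rests on a few compounds, and the source may have more. Where it says the series, first, only, none or still open, it means among the compounds named here.

Compound 1 `Cc1ccnc2nc(-c3cccc4ccccc34)cc(O)c12` is the starting point. In a functional assay on cells (Tumor Cell line, Homo sapiens) for antiproliferative activity (on this read-out lower numbers stand for stronger inhibition of growth and higher numbers for weaker inhibition of growth), compound 1 gives 35.5 nM. Compound 2 `Cc1cc(C)c2c(O)cc(-c3cccc4ccccc34)nc2n1` differs from it by methyl in place of hydrogen on an aromatic carbon, a change that made a large step, a 30-fold higher number from compound 1 to compound 2 (1.47 log units; beyond the scatter), so in this assay compound 2 gives 1050 nM. Compound 3 `Cc1ccc2c(O)cc(-c3ccc4ccccc4c3)nc2n1` has a core built from the same atoms as compound 1, joined differently; the difference between the two cores is not broken down here. In this assay compound 3 gives 4570 nM, the highest number of the three measured. Compound 4 `Cc1cc(C)c2c(O)cc(-c3ccc4ccccc4c3)nc2n1` is not yet measured and differs from compound 3 by methyl in place of hydrogen on an aromatic carbon. Among the measured compounds shown here, this is the same kind of change as the one from compound 1 to compound 2, but the surroundings differ: the earlier methyl sits next to the ring nitrogen and para to a fused ring, whereas the new one sits ortho to a fused ring and opposite the ring nitrogen. Because of the large step of a 30-fold higher number from compound 1 to compound 2 (1.47 log units; beyond the scatter) a weakening is expected again, though the different place argues for a smaller step, estimated as a 4.4-fold higher number from compound 3 to compound 4 (0.64 log units; beyond the scatter). Compound 4 is therefore expected to give about 20000 nM, somewhere between 5000 nM and 100000 nM.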

Compound 4, concentration for 50% growth inhibition: 13500 nM
For compound 4 the middle estimate is 1.5-fold (0.17 log units) above the measured one; the range from low to high includes it.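

In this assay the methyl again weakens growth inhibition on the second core (a 3.0-fold higher number from compound 3 to compound 4 (0.47 log units; beyond the scatter)). The direction of the change carries over from one core to the other, but its size does not: the same change on two cores in this assay, a 30-fold higher number (1.47 log units; beyond the scatter) from compound 1 to compound 2 and a 3.0-fold higher number (0.47 log units; beyond the scatter) from compound 3 to compound 4, 10-fold (1.00 log units) apart, beyond the scatter of two such steps. A step measured on one core is therefore a poor guide to the size of the step on another, and these two pairs alone do not show which feature of the cores sets the gap.

Left open is how an ethyl group, an amine or a carboxylic acid in place of the methyl would affect growth inhibition. Also open, as far as these compounds go, is whether the weakening would recur on any further core.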